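This account rests on a few compounds, and the source may have more. Where it says the series, first, only, none or still open, it means among the compounds named here.

In a functional assay on U-373MG ATCC cells (Homo sapiens) for inhibition, read by MTT assay, with a stated time of 72 h (on this read-out lower numbers stand for stronger inhibition of growth and higher numbers for weaker inhibition of growth), three compounds with a shared core have been measured: compound 1 `COC(=O)/C=C/C1=CC[C@H]2C(C)(C)CCC[C@]2(C)[C@H]1C=O` gives 22000 nM and compound 2 `CCOC(=O)/C=C/C1=CC[C@H]2C(C)(C)CCC[C@]2(C)[C@H]1C=O` gives 37000 nM while compound 3 `CCOC(=O)/C(C)=C/C1=CC[C@H]2C(C)(C)CCC[C@]2(C)[C@H]1C=O` gives 37000 nM on the same read-out. Compound 2 therefore stands level with compound 3, and compound 1 is no further from it than the usual scatter of repeated measurements.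

Compound 4 `CC(C)(C)OC(=O)/C=C/C1=CC[C@H]2C(C)(C)CCC[C@]2(C)[C@H]1C=O` has not been measured yet. Its difference from compound 2 (tert-butyl in place of ethyl on an oxygen next to a carbonyl group) is tert-butyl in place of ethyl on an oxygen next to a carbonyl group. For the measured compounds named here, only one measured step touches this same chain: a 1.7-fold higher number from compound 1 to compound 2 (0.23 log units; within the scatter) stays within the scatter. Going by the values given here, that step is only methyl in place of hydrogen, and no measured compound carries a tert-butyl, so the data offer no direction. No step beyond the scatter is expected in this assay although the uncertainty is real. The estimate amounts to a 1.1-fold higher number from compound 2 to compound 4 (0.03 log units; within the scatter) as the expected move. Compound 4 is expected at about 40000 nM with an estimated range from 18000 nM to 80000 nM on this read-out.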

Compound 4, concentration for 50% growth inhibition: 40000 nM
Compound 4: the middle estimate sits on the measured number at the digits printed, within the range that was stated.
By their numbers in this assay, from the lowest: compounds 1, 2, 3 and 4 (each within the scatter of the next).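

In this assay, tert-butyl in place of ethyl on an oxygen next to a carbonyl group gives a 1.1-fold higher number from compound 2 to compound 4 (0.03 log units; within the scatter), and tert-butyl in place of methyl at the same place gives a 1.8-fold higher number from compound 1 to compound 4 (0.26 log units; within the scatter). The earlier step compared only methyl and ethyl, whereas these steps show that a group of 4 heavy atoms, in place of 1 with 2, still leaves the number within the scatter, so methyl, ethyl and tert-butyl are not told apart here. Nothing available explains why these groups read alike.

Open, going by these compounds, is whether a different kind of group at this place, such as a benzyl group or a chain ending in an amine, would move the number beyond the scatter. On these data alone, a free carboxylic acid in place of these esters is equally open.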